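The source may hold more compounds than are shown below. What is called first, only, known or untested is meant among the compounds shown, and "the series" means these compounds.

The measured compounds:

Compound 1, `COc1ccc(C2=NN(C3=NC(=O)/C(=C4\C(=O)Nc5ccc(Br)cc54)S3)C(c3ccc(OC)cc3)C2)cc1`: 200 nM
Compound 2, `COc1ccc(C2=NN(C3=NC(=O)/C(=C4\C(=O)Nc5ccc(Cl)cc54)S3)C(c3ccc(OC)cc3)C2)cc1`: 200 nM
Compound 3, `CN(C)c1ccc(C2CC(c3ccccc3)=NN2C2=NC(=O)/C(=C3\C(=O)Nc4ccc(Br)cc43)S2)cc1`: 220 nM

In a functional assay on cells (Cancer cell lines, Homo sapiens) for cytotoxicity, read by sulforhodamine B assay, with a stated time of 48 h (a lower number here means a stronger inhibitor of growth, a higher number a weaker inhibitor of growth), compound 1 gives 200 nM and compound 2 gives 200 nM. The change between them is chloro in place of bromo on an aromatic carbon and the step it made is no change at the digits printed from compound 1 to compound 2 (within the scatter). Compound 3 rests on a different core; the difference between its core and that of compound 1 is not broken down here. In this assay compound 3 gives 220 nM, which lies within the scatter of the values of compound 1 and compound 2.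

Compound 4, `CN(C)c1ccc(C2CC(c3ccccc3)=NN2C2=NC(=O)/C(=C3\C(=O)Nc4ccc(Cl)cc43)S2)cc1`, has not yet been tested in this assay. It differs from compound 3 by chloro in place of bromo on an aromatic carbon, the same change as that from compound 1 to compound 2, at a place described in the same words. Because no change at the digits printed from compound 1 to compound 2 (within the scatter) the same change is expected to be flat here as well. The step it means for compound 4 is estimated as no change at the digits printed from compound 3 to compound 4 (within the scatter), with the note that this rests on a single measured pair. Compound 4 is therefore estimated at 220 nM, with a range from 110 nM to 440 nM.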

Compound 4, concentration for 50% growth inhibition: 210 nM
For compound 4 the middle estimate is 1.0-fold (0.02 log units) above the measured one; measured number inside the range.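

In this assay, chloro in place of bromo on an aromatic carbon gave a 1.0-fold lower number from compound 3 to compound 4 (0.02 log units; within the scatter). Set beside the earlier pair, the change behaves alike on both cores: the same change on two cores in this assay, no change at the digits printed (within the scatter) from compound 1 to compound 2 and a 1.0-fold lower number (0.02 log units; within the scatter) from compound 3 to compound 4, 1.0-fold (0.02 log units) apart, within the scatter of two such steps. This shows that the swap stayed flat at this one place on these two cores in this one assay, but it does not show that it would stay flat on a further core or at another place on the ring, and it says nothing about how the two halogens compare in any other measurement.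

The compounds shown leave open what that aromatic carbon would tolerate beyond the two halogens, such as an amine or a carboxylic acid in place of chloro or bromo. They also leave open what a longer chain would do in place of the methoxy groups of compound 1 or the dimethylamino group of compound 3.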